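The compounds below may be only part of what the source reports. "The series", "measured", "known", "first", "only" and "open" are said of these compounds alone.

Working notes on the series. Among the compounds with values here, compound 1 `COc1ccc(-c2cc(C)c3ncc(CSCCc4ccccc4)n3c2)cc1` has the higher of the two numbers so far in an ADME assay on HEL cells (Homo sapiens) for cytotoxicity, with a stated time of 3 days (on this read-out lower numbers stand for higher toxicity in this test and higher numbers for lower toxicity in this test), giving 25.8 ug/mL. Its nearest neighbour is compound 2 `COc1ccc(-c2cc(C)cn3c(CSCCc4ccccc4)cnc23)cc1`, which in this assay gives 19.6 ug/mL; the two values lie within the scatter of each other, so no order between compound 1 and compound 2 can be read from them. Compound 3 `Cc1cc(-c2ccccc2O)cn2c(CSCCc3ccccc3)cnc12` is not yet measured. It differs from compound 1 in one place: 2-hydroxyphenyl in place of 4-methoxyphenyl on an aromatic carbon. Within the data shown here, no step between measured compounds of this kind is available, so the size of this change on this assay cannot be taken from the series. The expectation is a step of no more than the usual scatter, in no fixed direction, since the two measured compounds themselves sit within it. The estimate for compound 3 in this assay is 25 ug/mL, with a range from 12 ug/mL to 50 ug/mL, which corresponds to an expected 1.0-fold lower number from compound 1 to compound 3 (0.01 log units; within the scatter).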

Compound 3, half-maximal cytotoxic concentration: > 50 ug/mL
Compound 3 gave a limit, no number; the forecaster's own chance of this, stated with the estimate: 20%; middle value at least 2.0-fold (0.30 log units) from the limit.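

Compound 3 gives only a limit in this assay, > 50 ug/mL, and not a number. Within the data shown here, the earlier compounds both carry 4-methoxyphenyl at this aromatic carbon, so this is the first reading of a change there: 2-hydroxyphenyl in place of 4-methoxyphenyl gives an at least 1.9-fold higher number from compound 1 to compound 3 (0.28 log units; that floor lies within the scatter), which shows no rise in toxicity in this test, while the true size of the step stays unknown and may be larger than that floor. This limit is the only one among the compounds shown: the limit of > 50 ug/mL in this assay, at which 1 of the 3 values shown sits.

The compounds shown leave open whether the hydroxyl, its place on the phenyl ring or the loss of the methoxy group accounts for the result, as 4-hydroxyphenyl and 2-methoxyphenyl are not among them. Going by these compounds, how an amine or a carboxylic acid on that phenyl ring would read in this assay also stays open.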